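A Third Methoxy on the Carbonyl-Side Ring

The source may hold more compounds than are shown below. What is called first, only, known or untested is meant among the compounds shown, and "the series" means these compounds.

Measured so far in a functional assay on OVCAR-8 cells (Homo sapiens) for inhibition, read by sulforhodamine B assay, with a stated time of 48 h; on this read-out higher numbers stand for weaker inhibition of growth and lower numbers for stronger inhibition of growth:
compound 1 `COc1ccc(C(=O)/C=C/c2cc(-c3cc(OC)c(OC)c(OC)c3)n[nH]2)cc1OC`: 2730 nM
compound 2 `COc1cc(-c2cc(/C=C/C(=O)c3ccc(F)c(F)c3)[nH]n2)cc(OC)c1OC`: 17300 nM

Compound 1 stands lowest of the two numbers in this assay, giving 2730 nM. Compound 2 gives 17300 nM. Within the data shown here, the only measured step, a 6.3-fold higher number from compound 1 to compound 2 (0.80 log units; beyond the scatter), concerns the ring on the carbonyl carbon, where a 3,4-difluorophenyl replaces a 3,4-dimethoxyphenyl. Compound 3 `COc1cc(C(=O)/C=C/c2cc(-c3cc(OC)c(OC)c(OC)c3)n[nH]2)cc(OC)c1OC` differs from compound 1 by methoxy in place of hydrogen on an aromatic carbon, ortho to a methoxy group and meta to a methoxy group. Among the measured compounds shown here, no measured step tests this change, so compound 3 is expected to show a 1.2-fold lower number from compound 1 to compound 3 (0.09 log units; within the scatter), nothing clearly beyond the scatter. Compound 3 is estimated at 2200 nM, between 600 nM and 8000 nM.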

Compound 3, concentration for total growth inhibition: 3280 nM
Beside the measured number, compound 3's estimate is 1.5-fold (0.17 log units) below it; the measured number falls inside the stated range.
By their numbers in this assay, from the lowest: compounds 1 and 3 (each within the scatter of the next); then compound 2.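

Methoxy in place of hydrogen on this aromatic carbon, ortho to a methoxy group, gives a 1.2-fold higher number from compound 1 to compound 3 (0.08 log units; within the scatter) in this assay, so this position takes the added methoxy without a step beyond the scatter. The step that swaps the whole ring, a 6.3-fold higher number from compound 1 to compound 2 (0.80 log units; beyond the scatter), is by contrast beyond the scatter. Nothing measured here bears on why this is so.

The compounds shown leave open whether an amine or a hydroxyl on this same carbon would also stay within the scatter of compound 1.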